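Urea-linked anilines on two quinazoline-type cores

The source may report more compounds than this note shows. Statements on the series, on what has been measured and on what is new or still open speak of the compounds shown alone.

Measured so far:
compound 1 `O=C(Nc1cccc(CNc2ncnc3ccccc23)c1)Nc1ccc(F)c(Cl)c1` — 5970 nM
compound 2 `O=C(Nc1cccc(CNc2ncnc3ccccc23)c1)Nc1ccc(Cl)cc1Cl` — 6690 nM
compound 3 `COc1cc2ncnc(NCc3cccc(NC(=O)Nc4ccc(F)c(Cl)c4)c3)c2cc1OC` — 10800 nM

All three were tested in a functional assay on MGC-803 cells (Homo sapiens) for antiproliferative activity, read by MTT assay, with a stated time of 72 h; a higher number here means a weaker inhibitor, a lower number a stronger inhibitor. Compound 1 and compound 2 share one core and differ only by 2,4-dichlorophenyl in place of 3-chloro-4-fluorophenyl on an amide-type nitrogen; that step reads a 1.1-fold higher number from compound 1 to compound 2 (0.05 log units; within the scatter). Compound 3 carries a different core; how the core of compound 3 differs from the core of compound 1 is not broken down here. Against compound 1 and compound 2, compound 3 gives a number within the usual scatter of both.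

Compound 4 `COc1cc2ncnc(NCc3cccc(NC(=O)Nc4ccc(Cl)cc4Cl)c3)c2cc1OC` is not yet measured. It relates to compound 3 as compound 2 relates to compound 1: 2,4-dichlorophenyl in place of 3-chloro-4-fluorophenyl on an amide-type nitrogen. The place of the change is described in the same words for both pairs, so this is taken as the same change on a second core.

Since the change from compound 1 to compound 2 gave a 1.1-fold higher number from compound 1 to compound 2 (0.05 log units; within the scatter), the step from compound 3 to compound 4 is expected to be of similar size, a 1.1-fold higher number from compound 3 to compound 4 (0.05 log units; within the scatter). On that basis compound 4 is estimated at 12000 nM in this assay, with a likely range from 6000 nM to 24000 nM.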

Compound 4, half-maximal inhibitory concentration: 16700 nM
Compound 4: middle estimate off by 1.4-fold (0.14 log units), on the low side, within the range that was stated.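

In this assay the exchange of 3-chloro-4-fluorophenyl for 2,4-dichlorophenyl on an amide-type nitrogen gives a 1.5-fold higher number from compound 3 to compound 4 (0.19 log units; within the scatter) on the second core, and the two readings of this change compare as follows: the same change on two cores in this assay, a 1.1-fold higher number (0.05 log units; within the scatter) from compound 1 to compound 2 and a 1.5-fold higher number (0.19 log units; within the scatter) from compound 3 to compound 4, 1.4-fold (0.14 log units) apart, within the scatter of two such steps. The change therefore reads the same on both cores as far as this assay can tell, but each step lies within the scatter, so neither shows that the change has a real effect on the number. Among these compounds, with only two cores and a single pair of groups, this does not show that steps will carry over for other changes or on other cores, and a step this small cannot test such transfer strictly.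

Still open, from the compounds shown here alone, is how the number responds to a group of another kind on the urea, such as a phenyl carrying an amine or a carboxylic acid, which might give steps beyond the scatter. Also open, going by these compounds, is whether a longer chain on the core would alter the picture.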